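Swapping a chloropiperidine for a methylpiperazine on the chain

This account rests on a few compounds, and the source may have more. Where it says the series, first, only, none or still open, it means among the compounds named here.

Compound 1 `CC1=NN(C(=O)COc2ccc(Cl)cc2)C(c2ccccc2O)C1` and compound 2 `CC1=NN(C(=O)CN2CCC(Cl)CC2)C(c2ccccc2O)C1` share one core and differ only at the saturated chain carbon bound to the carbonyl carbon. In a functional assay on PC-3 cells (Homo sapiens) for cytotoxicity, read by MTT assay, with a stated time of 48 h (on this read-out higher numbers stand for weaker inhibition and lower numbers for stronger inhibition), compound 1 gives 38800 nM, and compound 2 gives 34800 nM; the step of a 1.1-fold lower number from compound 1 to compound 2 (0.05 log units; within the scatter) leaves the two within the scatter of each other. Compound 3 `CC1=NN(C(=O)CN2CCN(C)CC2)C(c2ccccc2O)C1` carries 4-methylpiperazin-1-yl in place of 4-chloropiperidin-1-yl on a saturated chain carbon bound to a carbonyl carbon. Among the measured compounds shown here, the only step that bears on this place, a 1.1-fold lower number from compound 1 to compound 2 (0.05 log units; within the scatter), was small, so no change beyond the scatter is expected. Compound 3 is therefore estimated at 35000 nM (range 15000 nM to 80000 nM), a step of a 1.0-fold higher number from compound 2 to compound 3 (0.00 log units; within the scatter).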

Compound 3, half-maximal inhibitory concentration: 11800 nM
Estimate against measurement, compound 3: 3.0-fold (0.47 log units) above, outside the stated range (below it).
By their numbers in this assay, from the lowest: compound 3; then compounds 2 and 1 (each within the scatter of the next).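

In this assay this position, on a saturated chain carbon bound to a carbonyl carbon, now shows a change beyond the scatter: 4-methylpiperazin-1-yl in place of 4-chloropiperidin-1-yl gives a lower number (a 2.9-fold lower number from compound 2 to compound 3 (0.47 log units; beyond the scatter)), unlike the earlier exchange of 4-chlorophenoxy for 4-chloropiperidin-1-yl. Measured against 4-chlorophenoxy, the same group also gives a lower number (a 3.3-fold lower number from compound 1 to compound 3 (0.52 log units; beyond the scatter)). Nothing available explains these steps. The compounds shown leave open whether the second ring nitrogen or its methyl matters; a piperazin-1-yl without the methyl or a morpholin-4-yl at this place would help separate the two.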